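The source may hold more compounds than are shown below. What is called first, only, known or untested is meant among the compounds shown, and "the series" means these compounds.

Of the compounds shown here, two have been measured so far. Compound 1 `CC(C)OC(=O)N1CCC(Oc2ncnc3c2CCN3c2ccc(C#N)cc2F)CC1` gives 63.1 nM in a functional assay on CHO-K1 cells for agonist activity at Glucose-dependent insulinotropic receptor (Homo sapiens), read by a luciferase reporter, with a stated time of 5 h; on this read-out lower numbers stand for an effect already at smaller amounts and higher numbers for an effect only at larger amounts of compound. Compound 2 `CCCOC(=O)N1CCC(Oc2ncnc3c2CCN3c2ccc(S(C)(=O)=O)cc2F)CC1` gives 79.4 nM in this assay; compound 2 and compound 1 lie within the scatter of each other, so the two numbers show no real separation. Compound 3 `CS(=O)(=O)c1ccc(N2CCc3c(OC4CCN(C5=NCCCN5)CC4)ncnc32)c(F)c1` has not yet been measured. It differs from compound 2 in one place: a group of 6 heavy atoms (4 carbon, 2 nitrogen; one six-membered non-aromatic ring with 2 hetero atoms) in place of a group of 6 heavy atoms (4 carbon, 2 oxygen; no ring), on an amine nitrogen in a ring. For the measured compounds named here, no measured pair bears on this change, so only an expectation can be given. A step of modest size is expected, a 1.9-fold higher number from compound 2 to compound 3 (0.28 log units; within the scatter), possibly toward larger amounts. For compound 3 the estimate in this assay is 150 nM, with a range from 30 nM to 800 nM.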

Compound 3, half-maximal effective concentration: 2000 nM
For compound 3 the middle estimate is 13-fold (1.12 log units) below the measured one; measured number outside the range, above it.
By their numbers in this assay, from the lowest: compounds 1 and 2 (each within the scatter of the next); then compound 3.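

On the amine nitrogen in a ring, the series is not indifferent to the group carried: in this assay, putting the six-membered non-aromatic ring with 2 hetero atoms in place of propoxycarbonyl gives a 25-fold higher number from compound 2 to compound 3 (1.40 log units; beyond the scatter). Both groups have 6 heavy atoms, so an equal heavy-atom count does not preserve the number, although this single pair cannot separate the effect of the ring from that of the added hydrogen-bond donor. No available data explain the step. Still open, as far as these compounds go, is whether an open-chain guanidine or a urea on this nitrogen would stay close to compound 2, and whether the same change on the core of compound 1 would give a similar step.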